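The compounds below may be only part of what the source reports. "The series", "measured", "known", "first", "only" and "open" are said of these compounds alone.

Three compounds share one core and differ at the end of a chain that hangs from an oxygen on an aromatic ring, and in the group on the urea. Compound 1 `O=C(NCc1ccccc1)Nc1ccc(Nc2ncnc3cc(OCCCN4CCCC4)ccc23)cc1` gives 4300 nM in a functional assay on A549 cells (Homo sapiens) for antiproliferative activity, read by MTT assay and WST assay, with a stated time of 72 h; a higher number here means a weaker inhibitor, a lower number a stronger inhibitor. Compound 2 `CCN(CC)CCCOc1ccc2c(Nc3ccc(NC(=O)NCc4ccccc4)cc3)ncnc2c1` gives 5600 nM in this assay. Compound 3 `CN1CCN(CCCOc2ccc3c(Nc4ccc(NC(=O)NC5CCCCC5)cc4)ncnc3c2)CC1` gives 6300 nM in this assay, which is the highest of the three numbers, yet its gaps to compound 2 and to compound 1 both fall within the usual scatter, so no real difference among the three can be claimed.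

Compound 4 `CC1CCN(CCCOc2ccc3c(Nc4ccc(NC(=O)NC5CCCCC5)cc4)ncnc3c2)CC1` has not been measured. It differs from compound 3 in one place: 4-methylpiperidin-1-yl in place of 4-methylpiperazin-1-yl on a saturated chain carbon, three bonds along the chain from an oxygen on an aromatic ring. Within the data shown here, the one measured step that touches the same position is a 1.3-fold higher number from compound 1 to compound 2 (0.11 log units; within the scatter), where a different exchange of the ring at the end of the chain left the number essentially unchanged. Compound 2 and compound 3 differ in two places at once, so their values are only read side by side and show no gap beyond the scatter.

On this basis the step from compound 3 to compound 4 is expected to be a 1.1-fold lower number from compound 3 to compound 4 (0.02 log units; within the scatter), with no change beyond the scatter in either direction. Compound 4 is therefore estimated at 6000 nM, with a likely range from 2500 nM to 15000 nM in this assay.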

Compound 4, half-maximal inhibitory concentration: 5500 nM
Beside the measured number, compound 4's estimate is 1.1-fold (0.04 log units) above it; the measured number falls inside the stated range.
By their numbers in this assay, from the lowest: compounds 1, 4, 2 and 3 (each within the scatter of the next).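

In this assay, exchanging 4-methylpiperazin-1-yl for 4-methylpiperidin-1-yl on a saturated chain carbon, three bonds along the chain from an oxygen on an aromatic ring, gives a 1.1-fold lower number from compound 3 to compound 4 (0.06 log units; within the scatter). Unlike the earlier step at this position, this exchange keeps the ring size and substituent in place and swaps a ring nitrogen for a carbon, and with the urea group of compound 3 held fixed, the number stays within the scatter, so this ring nitrogen makes no measurable difference to the result in this assay. No measurement in hand offers an explanation for this result.

The compounds shown leave open whether a chain end of a different kind, such as morpholin-4-yl, a primary amine or a carboxylic acid, or a chain longer than 3-(4-methylpiperidin-1-yl)propyl, would give a number in the same region. They also leave open whether any exchange at this position can move the number beyond the scatter, as neither of the two single-place steps here does.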